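Lengthening the ester chain to compound 4

The source may hold more compounds than are shown below. What is called first, only, known or untested is meant among the compounds shown, and "the series" means these compounds.

Measured in a functional assay on A549 cells (Homo sapiens) for inhibition, with a stated time of 48 h, tested at 50 uM; a higher number here means more inhibition of growth at the concentration tested, a lower number less inhibition of growth:
Compound 1 `C=C[C@@](C)(/C=C/c1ccc(OC(C)=O)cc1)CCC=C(C)C` gives 72%
Compound 2 `C=C[C@@](C)(/C=C/c1ccc(OC(=O)CC)cc1)CCC=C(C)C` gives 42%
Compound 3 `C=C[C@@](C)(/C=C/c1ccc(OC(=O)CCCCC)cc1)CCC=C(C)C` gives 58%

Compound 3 (58%) stands second highest of the three, below compound 1 and above compound 2. The next compound, compound 4 (`C=C[C@@](C)(/C=C/c1ccc(OC(=O)CCCCCCCCCCCCCCC)cc1)CCC=C(C)C`), has not yet been measured. It differs from compound 3 by decyl in place of hydrogen on a saturated chain carbon, five bonds along the chain from a carbonyl carbon.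

Among the compounds with values here, three measured steps bear on this change, and they do not run one way. Growing the chain first gave a number 30 percentage points lower from compound 1 to compound 2 (beyond the scatter), whereas further growth gave a number 16 percentage points higher from compound 2 to compound 3 (beyond the scatter). Taken end to end, the series shows a number 14 percentage points lower from compound 1 to compound 3 (beyond the scatter). The change to compound 4 also goes well beyond any chain measured so far, so the direction is held only loosely.

A modest fall is expected, an estimated a number 16 percentage points lower from compound 3 to compound 4 (beyond the scatter). For compound 4 the estimated value in this assay is 42%, with an expected range from 18% to 66%.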

Compound 4, percent growth inhibition at one concentration: 61%
Estimate against measurement, compound 4: 19 percentage points below; the range from low to high includes it.
By their numbers in this assay, from the lowest: compound 2; then compounds 3 and 4 (each within the scatter of the next); then compound 1.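

In this assay, decyl in place of hydrogen on a saturated chain carbon, five bonds along the chain from a carbonyl carbon, gave a number 3 percentage points higher from compound 3 to compound 4 (within the scatter) and so left the growth inhibition effectively unchanged. Within the data shown here, this is the first chain extension that stays within the scatter, although it adds more carbon than either earlier extension, both of which moved the number beyond the scatter. At this position, then, a large addition of chain was tolerated in this assay, and nothing shown gives a reason for that.

The compounds shown leave open how chains of intermediate length between those of compound 3 and compound 4 behave, and whether a still longer chain would keep the number. They also leave open whether an amine or a carboxylic acid at the far end of the chain would change it.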